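A few compounds are considered here, and "the series" means these few. Any claim that something is new, unique, unknown or untested is made for them only; others in the source may bear on it.

Compound 1 `O=C1c2ccccc2C(=O)N1c1cc(F)cc(Oc2cccnc2)c1`: "not determined" (no result reported) in a functional assay on Flp-In T-REx293 cells for antagonist activity at Free fatty acid receptor 1 (Homo sapiens), read by calcium flux; on this read-out lower numbers stand for smaller maximal responses and higher numbers for larger maximal responses.
Compound 2 `CCCCc1ccc(NS(=O)(=O)c2ccc(F)cc2)cc1`: 68% in this assay.
Compound 3 `O=S(=O)(Nc1ccc(Oc2ccccc2)cc1)c1ccc(F)cc1`: 95% in this assay.

For the measured compounds named here, compound 3 stands highest of the two numbers; the only measured step is a number 27 percentage points higher from compound 2 to compound 3 (beyond the scatter). Compound 4 `Cc1ccc(S(=O)(=O)Nc2ccc(Oc3ccccc3)cc2)cc1` keeps the phenoxy side of compound 3 and differs only on the other aromatic ring: methyl in place of fluoro on an aromatic carbon. Going by the values given here, no measured step touches that ring, so the change from compound 2 to compound 3 gives no direct guide, and a swap of one small group for another is expected to leave the number close to that of compound 3. Compound 4 is therefore estimated at 90% (range 72% to 100%), an expected step of a number 5 percentage points lower from compound 3 to compound 4 (within the scatter) that stays within the scatter.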

Compound 4, largest response reached (reported as Imax), in percent of the reference or control that the assay uses: 100%
Beside the measured number, compound 4's estimate is 10 percentage points below it; the range from low to high includes it.
By their numbers in this assay, from the lowest: compound 2; then compounds 3 and 4 (each within the scatter of the next).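

In this assay, for the compounds shown here, the change from 4-fluorophenyl to 4-methylphenyl gives a number 5 percentage points higher from compound 3 to compound 4 (within the scatter), the only measured step at this position. With the phenoxy group kept, methyl and fluoro on this aromatic carbon, para to a large group, cannot be told apart, whereas the earlier step concerned only the other aromatic ring. No evidence is available on why the two groups read alike. From the compounds shown here alone, whether an amine or a carboxylic acid on this carbon would also hold the response remains open, as does whether methyl in place of fluoro would read the same with butyl in place of phenoxy.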